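Chloro for hydrogen on the core of compound 2

A few compounds are considered here, and "the series" means these few. Any claim that something is new, unique, unknown or untested is made for them only; others in the source may bear on it.

Measured so far in a functional assay on LOX IMVI cells (Homo sapiens) for cytotoxicity, read by sulforhodamine B assay, with a stated time of 48 h; a lower number here means that less compound is tolerated, a higher number that more compound is tolerated:
compound 1 `ClCc1cccc(Cn2cnc3c(Cl)ncnc32)c1` — 27500 nM
compound 2 `ClCc1ccccc1Cn1cnc2ncnc(Cl)c21` — 7070 nM

Compound 2 gives the lowest of the two numbers recorded in this assay, with compound 1 giving a higher value in this assay; the gap between the two lies beyond the scatter, so compound 2 tolerates less material than compound 1. The two compounds differ in where the chloromethyl-bearing ring is joined, and no single-point comparison between measured compounds is at hand.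

The next compound, compound 3 `ClCc1ccccc1Cn1cnc2nc(Cl)nc(Cl)c21`, keeps the whole of compound 2 and carries one change: chloro in place of hydrogen on an aromatic carbon. Nothing measured in the series isolates the effect of this second chloro group, so the step expected from compound 2 to compound 3 in this assay is a small one, if any, pointing to a lower number but not beyond the scatter. On that basis compound 3 is estimated at 5000 nM in this assay, with a range from 1500 nM to 17000 nM, which amounts to an expected step of a 1.4-fold lower number from compound 2 to compound 3 (0.15 log units; within the scatter).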

Compound 3, concentration lethal to 50% of the cells: 720 nM
The estimate for compound 3 lay 6.9-fold (0.84 log units) above the measured number, outside the stated range (below it).
By their numbers in this assay, from the lowest: compound 3; then compound 2; then compound 1.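

In this assay, among the compounds shown here, chloro in place of hydrogen on the aromatic carbon between two ring nitrogen atoms gives a 9.8-fold lower number from compound 2 to compound 3 (0.99 log units; beyond the scatter), the first change at a single place that can be read. This position therefore responds to substitution: one added heavy atom, with no ring, no hydrogen-bond donor or acceptor and no net charge, moves the number beyond the scatter. No measurement at hand accounts for the size of this step.

Going by these compounds, whether the step is specific to chloro or would also follow from another group at this carbon, such as an amine or a methoxy group, remains open. Also open, on these data alone, is whether the same change would give a similar step on the scaffold of compound 1, where the chloromethyl-bearing ring is joined differently.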